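This account rests on a few compounds, and the source may have more. Where it says the series, first, only, none or still open, it means among the compounds named here.

In an ADME assay on MT2 cells (Homo sapiens) for cytotoxicity (on this read-out higher numbers stand for lower toxicity in this test and lower numbers for higher toxicity in this test), three compounds have been measured so far. Compound 1 `CC(C)=CCOc1cc(Nc2ncnc(Cl)n2)ccc1C#N` gives > 100000 nM, which is a limit of the assay rather than a number. One of the three values therefore sits at the limit of > 100000 nM in this assay, at which 1 of the 3 values shown sits. Compound 2 `CC(C)=CCOc1cc(Nc2nccc(N)n2)ccc1Cl` gives 500 nM. Compound 3 `CNc1ccnc(Nc2ccc(Cl)c(OCC=C(C)C)c2)n1` gives 690 nM. Among the measured compounds shown here, the one measured step runs a 1.4-fold higher number from compound 2 to compound 3 (0.14 log units; within the scatter), so compound 3 and compound 2 sit together within the scatter, and the remaining value is the limit of compound 1; compound 3 thus stands alongside compound 2 among the numbers.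

Compound 4 `COCc1ccnc(Nc2ccc(Cl)c(OCC=C(C)C)c2)n1` differs from compound 3 by methoxymethyl in place of methylamino on an aromatic carbon. For the measured compounds named here, the only measured step, a 1.4-fold higher number from compound 2 to compound 3 (0.14 log units; within the scatter), concerns methyl in place of hydrogen on a nitrogen on an aromatic ring and lies within the scatter; no measured step touches an exchange of methylamino for methoxymethyl on an aromatic carbon, so the data give no direction for this change. The number of compound 3 is therefore expected to carry over with little movement. Compound 4 is expected to give 700 nM, with a range from 250 nM to 2500 nM. The expected step is a 1.0-fold higher number from compound 3 to compound 4 (0.01 log units; within the scatter), within the scatter, with the range widened for the absence of a directly comparable step.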

Compound 4, half-maximal cytotoxic concentration: > 25000 nM
Compound 4 ended at the assay's limit (the forecaster's own chance of this, stated with the estimate: 10%); middle value at least 35-fold (1.55 log units) from the limit.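

On the aromatic carbon next to the ring nitrogen, this assay turns out to be highly sensitive to the group: replacing methylamino with methoxymethyl gives an at least 36-fold higher number from compound 3 to compound 4 (1.55 log units; beyond the scatter), and replacing amino with methoxymethyl gives an at least 50-fold higher number from compound 2 to compound 4 (1.69 log units; beyond the scatter). The earlier step at this carbon, a 1.4-fold higher number from compound 2 to compound 3 (0.14 log units; within the scatter), had shown no such sensitivity, so the large change appears only when the ring-bound nitrogen of amino and methylamino gives way to the carbon-linked methoxymethyl, which moves the read-out towards lower toxicity in this test. For compound 4 the read-out is a limit of the assay and not a number: the limit of > 25000 nM in this assay, at which 1 of the 4 values shown sits.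

The exchange changes several things at once, including the atom bound to the ring, the hydrogen-bond donor count and the size of the group, and the compounds shown do not separate these. As far as these compounds go, a dimethylamino group would keep a ring-bound nitrogen with no hydrogen on it, while an ethyl or a hydroxymethyl group would test a carbon link without the ether oxygen, so these remain open comparisons for this position.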